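A longer chain on the imine nitrogen of compound 3

This account rests on a few compounds, and the source may have more. Where it says the series, first, only, none or still open, it means among the compounds named here.

Of the compounds shown here, three with the same shared core have been tested in a functional assay on the whole organism with Rattus norvegicus as the target; on this read-out lower numbers stand for an effect already at smaller amounts and higher numbers for an effect only at larger amounts of compound. Compound 1, `CCCCCCc1ccc2nc(N)sc2c1`, gives 7 mg/kg in this assay. Compound 2, `Nc1nc2ccc(SC(F)(F)F)cc2s1`, gives 8 mg/kg. Compound 3, `N#CCn1c(=N)sc2cc(OC(F)(F)F)ccc21`, gives 3.5 mg/kg, the lowest of the three numbers: its gap to compound 1 is within the usual scatter, so no order between those two can be claimed, while its gap to compound 2 lies beyond the scatter.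

Compound 4, `C[S+]([O-])CCCn1c(=N)sc2cc(OC(F)(F)F)ccc21`, has not yet been measured in this assay. It differs from compound 3 in one place: a group of 5 heavy atoms (3 carbon, 1 oxygen, 1 sulfur; no ring) in place of a group of 2 heavy atoms (1 carbon, 1 nitrogen; no ring), on a saturated chain carbon bound to an aromatic nitrogen. Among the compounds with values here, no step between two measured compounds shows what such a change does to the dose in this assay, so the expectation rests on compound 3 alone.

Without a measured step of this kind to lean on, the change from compound 3 to compound 4 is expected to move the dose little, if at all, with the step of a 1.4-fold higher number from compound 3 to compound 4 (0.15 log units; within the scatter) expected to stay within the scatter. Compound 4 is therefore estimated to give about 5 mg/kg in this assay, with a likely range from 2 mg/kg to 15 mg/kg.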

Compound 4, dose for half-maximal effect: 2.3 mg/kg
For compound 4 the middle estimate is 2.2-fold (0.34 log units) above the measured one, and the stated range covers the measured number.
By their numbers in this assay, from the lowest: compounds 4, 3, 1 and 2 (each within the scatter of the next, the first and the last beyond it).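

Within the data shown here, the step at this place, a saturated chain carbon bound to an aromatic nitrogen, gives the first direct look at what this position accepts: exchanging the cyano group for a group of 5 heavy atoms (3 carbon, 1 oxygen, 1 sulfur) gives a 1.5-fold lower number from compound 3 to compound 4 (0.18 log units; within the scatter) in this assay. The group goes from 2 heavy atoms to 5 heavy atoms and loses its triple bond, yet the dose stays within the normal spread of repeated measurements, so in this pair the change leaves the read-out without a clear shift. Nothing measured here accounts for how closely the two compounds agree.

A single pair cannot separate the effect of chain length from that of the sulfur and oxygen atoms, and it cannot show how far this position would accept other groups. A plain carbon chain with no sulfur or oxygen, a longer chain, or a chain carrying an amine or a carboxylic acid remains an open case, and any of these could either keep the dose in this range or move it clearly away.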